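A few compounds are considered here, and "the series" means these few. Any claim that something is new, unique, unknown or untested is made for them only; others in the source may bear on it.

Three compounds share one core and were tested in an assay on LX2 cells for inhibition of COL1A1 promoter (Homo sapiens), read by a luciferase reporter, with a stated time of 24 h, tested at 50 uM; a lower number here means a weaker effect, a higher number a stronger effect of the compound at the concentration tested. Compound 1 `Cc1cc(OCCCCCCC[N+]23CCN(CC2)CC3)ccc1-n1cc(C(=O)Nc2cc(F)cc(F)c2)c(=O)c2ccc(N(C)C)nc21` was reported as "not active" (no number reported), with no number attached. Compound 2 `Cc1cc(OCCCCCCC[N+]23CCN(CC2)CC3)cc(-n2cc(C(=O)Nc3cc(F)cc(F)c3)c(=O)c3ccc(N(C)C)nc32)c1` gives 5.52%, the lowest of the two numbers that were reported. Compound 3 `CN(C)c1ccc2c(=O)c(C(=O)Nc3cc(F)cc(F)c3)cn(-c3ccc(Cl)c(OCCCCCCC[N+]45CCN(CC4)CC5)c3)c2n1` gives 18.7%, a result that stands above compound 2 by more than the usual scatter. Compound 4 `Cc1cc(OCCCCCCC[N+]2(C)CCCC2)cc(-n2cc(C(=O)Nc3cc(F)cc(F)c3)c(=O)c3ccc(N(C)C)nc32)c1` has not yet been measured. It differs from compound 2 in one place: a group of 6 heavy atoms (5 carbon, 1 nitrogen; one five-membered non-aromatic ring with 1 hetero atom) in place of a group of 8 heavy atoms (6 carbon, 2 nitrogen; 2 six-membered non-aromatic rings with 2 hetero atoms each), on a saturated chain carbon, seven bonds along the chain from an oxygen on an aromatic ring. Within the data shown here, no two measured compounds differ from each other in only one place, so no measured step shows directly what such an exchange does. With the whole set giving either a weak effect or no reported number, a change at this point is expected to leave the result close to that of compound 2, so the step of a number 2.5 percentage points higher from compound 2 to compound 4 (within the scatter) is expected to stay within the scatter. Compound 4 is therefore estimated at 8%, within a range from 0% to 22%.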

Compound 4, a percentage reported as inhibition, at one concentration (the size of the read-out at that concentration, not a potency): 35.4%
Estimate against measurement, compound 4: 27.4 percentage points below; the whole stated range lies below it.
By their numbers in this assay, from the lowest: compound 2; then compound 3; then compound 4.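

Among these compounds, exchanging the group at the chain end is the first single-place change in this set, and in this assay it gives a number 29.9 percentage points higher from compound 2 to compound 4 (beyond the scatter), so this position is not indifferent to what stands there. Both groups have a net charge of +1, which means the difference appears with that count unchanged, while the hydrogen-bond acceptors go from 1 to 0 and the heavy atoms from 8 to 6. No measurement here bears on why the read-out rises with this exchange.

One step cannot separate ring size from the loss of the second nitrogen, and a piperidine ring or a trimethylammonium group at the same chain end could help to tell them apart. On these data alone, it also remains open whether the same exchange would raise the read-out for compound 1 or compound 3.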